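Swapping Propyl for Cyclopropyl on Compound 1

This account rests on a few compounds, and the source may have more. Where it says the series, first, only, none or still open, it means among the compounds named here.

Measured so far:
Compound 1 `CCCNc1nc(NCCCCOc2nc(NCCC)nc(Nc3ccccc3)n2)nc(Nc2ccccc2)n1`: 216000 nM
Compound 2 `CC(C)(C)Nc1nc(NCCCCOc2nc(Nc3ccccc3)nc(NC(C)(C)C)n2)nc(Nc2ccccc2)n1`: 198000 nM

Both values come from an ADME assay on Vero cells (Chlorocebus sabaeus) for cytotoxicity, read by MTT assay, with a stated time of 72 h; on this read-out higher numbers stand for lower toxicity in this test and lower numbers for higher toxicity in this test. There, compound 1 stands at 216000 nM, within the scatter of compound 2 at 198000 nM. For the measured compounds named here, the two numbers alone therefore set no order between the compounds.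

Compound 3 `CCCNc1nc(NCCCCOc2nc(Nc3ccccc3)nc(NC3CC3)n2)nc(Nc2ccccc2)n1` has not yet been measured in this assay. It has cyclopropyl in place of propyl on a nitrogen on an aromatic ring, the change from propylamino to cyclopropylamino: cyclopropyl in place of propyl on a nitrogen on an aromatic ring. Going by the values given here, no step between measured compounds shows what such a change does, so the expectation rests only on the two values at hand. No shift beyond the scatter is expected, in either direction. The estimate is a 1.1-fold lower number from compound 1 to compound 3 (0.06 log units; within the scatter), which is expected to stay within the scatter. For compound 3 the estimated value is 190000 nM, with an expected range of 85000 nM to 380000 nM.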

Compound 3, half-maximal cytotoxic concentration: 18200 nM
Compound 3: the middle estimate sits 10-fold (1.02 log units) above what was measured, and the stated range ends above it.
By their numbers in this assay, from the lowest: compound 3; then compounds 2 and 1 (each within the scatter of the next).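

In this assay, the position is shown to be sensitive to this change, with cyclopropyl in place of propyl on a nitrogen on an aromatic ring giving a 12-fold lower number from compound 1 to compound 3 (1.07 log units; beyond the scatter) and thus higher toxicity in this test. The earlier compounds shown here set no order and offered no step, whereas this pair differs in one place only, and the count of heavy atoms stays the same while a three-membered non-aromatic ring enters. Nothing at hand explains why this swap has so large an effect.

The compounds shown leave open whether the ring itself matters, since neither isopropyl nor cyclobutyl stands at this nitrogen among them. They also leave open whether the same swap at the remaining propylamino group of compound 3 would shift the number further.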